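Piperidine for Methylpyrazole: a Stability Outlook

The source may hold more compounds than are shown below. What is called first, only, known or untested is meant among the compounds shown, and "the series" means these compounds.

Measured compounds:
Compound 1 `CCc1ccccc1-c1cc(C(=O)N[C@@H](CCN2CCCCC2)CC(=O)NC2CCC2)nn1C1CCCC1` gives 76.5% in an ADME assay on microsomes from liver (Rattus norvegicus, strain Sprague-Dawley) for metabolic stability, read by LC-MS, using NADPH, with a stated time of 30 min, tested at 1 uM; on this read-out higher numbers stand for a more stable compound and lower numbers for a less stable compound.
Compound 2 `O=C(C[C@H](CCN1CCCCC1)NC(=O)c1cc(-c2cccs2)n(C2CCCC2)n1)NC1CCC1` gives "nd" (no result reported) in this assay, meaning no number was reported.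
Compound 3 `Cc1cnn(CC[C@@H](CC(=O)NC2CCC2)NC(=O)c2cc(-c3ccccc3C(F)(F)F)n(C3CCCC3)n2)c1` gives "nd" (no result reported) in this assay, again with no number reported.

The account follows the step from compound 3 to compound 4. Compound 3 stands without a single number in this assay, and it is not alone in this: compound 2 is a further entry for which no number came back. The only firm anchor among the measured compounds is therefore compound 1, with its 76.5% in this assay.

Compound 4 `O=C(C[C@H](CCN1CCCCC1)NC(=O)c1cc(-c2ccccc2C(F)(F)F)n(C2CCCC2)n1)NC1CCC1` differs from compound 3 in one place, (piperidin-1-yl in place of 4-methyl-1H-pyrazol-1-yl on a saturated chain carbon, three bonds along the chain from an amide-type nitrogen). Going by the values given here, because no pair of measured compounds differs in exactly one place, no step of this kind has been seen in this assay, and nothing can be said about the size or direction of the change from compound 3 itself.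

The expectation for compound 4 rests on compound 1, which shares the 2-(piperidin-1-yl)ethyl chain and gives 76.5% in this assay. On that basis compound 4 is estimated at 70% in this assay, with a range expected from 40% to 95%.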

Compound 4, percent of the compound remaining: 74.6%
The estimate for compound 4 lay 4.6 percentage points below the measured number; the range from low to high includes it.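

In this assay, with the 2-(piperidin-1-yl)ethyl chain kept, trifluoromethyl in place of ethyl on an aromatic carbon gives a number 1.9 percentage points lower from compound 1 to compound 4 (within the scatter), so on this read-out the two groups cannot be told apart on the shared core. This gives a second number for a compound carrying piperidin-1-yl on the saturated chain carbon, but the change from 4-methyl-1H-pyrazol-1-yl to piperidin-1-yl itself still cannot be read, since compound 3 has no number and the step has only one measured end. Nothing available here bears on why compound 1 and compound 4 read so alike.

The compounds shown leave open how the read-out would respond to another group at this place on the chain, such as morpholin-4-yl or a dimethylamino group, and so whether piperidin-1-yl matters there at all. They also leave open whether a chlorine or a methoxy group on the same aromatic carbon would read like ethyl and trifluoromethyl.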